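The compounds below may be only part of what the source reports. "The series", "measured", "known", "first", "only" and "open" are said of these compounds alone.

Within the data shown here, compound 1 `[O-][n+]1nc(NCOCc2ccccc2)[n+]([O-])c2ccccc21` is one of only two measured compounds, and in a functional assay on PC-3 cells (Homo sapiens) for cytotoxicity, read by MTT assay, with a stated time of 72 h (on this read-out lower numbers stand for stronger inhibition and higher numbers for weaker inhibition), compound 1 gives 11900 nM. Among the measured compounds shown here, its sole measured neighbour is compound 2 `CC(OCNc1n[n+]([O-])c2ccccc2[n+]1[O-])c1ccccc1`, which in this assay gives 10700 nM; the change from compound 1 to compound 2 is a 1.1-fold lower number from compound 1 to compound 2 (0.05 log units; within the scatter), so the two numbers sit within the scatter of each other. Compound 3 `CCCCCOCNc1n[n+]([O-])c2ccccc2[n+]1[O-]` differs from compound 1 by butyl in place of phenyl on a saturated chain carbon bound to an oxygen on a saturated carbon. For the measured compounds named here, no measured step swaps a ring for a chain, so the only guide is that the one small change seen left the number essentially unchanged. The expectation for compound 3 is therefore 12000 nM, in a range from 5000 nM to 30000 nM, a step of a 1.0-fold higher number from compound 1 to compound 3 (0.00 log units; within the scatter) expected to remain within the scatter.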

Compound 3, half-maximal inhibitory concentration: 8510 nM
For compound 3 the middle estimate is 1.4-fold (0.15 log units) above the measured one; low and high end bracket the measured number.
By their numbers in this assay, from the lowest: compounds 3, 2 and 1 (each within the scatter of the next).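

In this assay, the change gives a 1.4-fold lower number from compound 1 to compound 3 (0.15 log units; within the scatter) and so leaves the number essentially where it was. The earlier step added only a methyl, whereas this one removes the whole aromatic ring on a saturated chain carbon bound to an oxygen on a saturated carbon, so a ring here is not needed to keep a number of this size. Nothing at hand explains this result.

On these data alone, whether an amine or a carboxylic acid at the end of this chain, or a longer chain, would also leave the number unchanged remains open.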